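A few compounds are considered here, and "the series" means these few. Any claim that something is new, unique, unknown or untested is made for them only; others in the source may bear on it.

In a functional assay on CCRF-CEM cells (Homo sapiens) for inhibition (on this read-out lower numbers stand for stronger inhibition and higher numbers for weaker inhibition), compound 1 `CCC(C)C(NC(=O)n1nnc2ccccc21)C(=O)NCc1ccccc1` gives 164000 nM. Compound 2 `CC(C)C(NC(=O)n1nnc2ccccc21)C(=O)NC1CCCC1` is reported only as a limit of the assay, namely > 200000 nM. This limit is the one given in the limit of > 200000 nM in this assay, at which 1 of the 2 values shown sits. Compound 3 `CCC(C)C(NC(=O)n1nnc2ccccc21)C(=O)NC1CCCC1` has not yet been measured. Compared with compound 2 it carries methyl in place of hydrogen on a saturated chain carbon, three bonds along the chain from an amide-type nitrogen and a carbonyl carbon. No directly measured step links any two of these compounds, and the two values on hand come from structures that differ in both the amide side and the chain side, so together they show only that both sit high on this read-out. For this change a step of an at least 1.1-fold lower number from compound 2 to compound 3 (0.04 log units; that floor lies within the scatter) is expected that stays within the usual scatter, with no clear direction. Compound 3 is therefore estimated at 180000 nM, with a range from 80000 nM to 350000 nM, and a result reported only as a limit would not be surprising.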

Compound 3, half-maximal inhibitory concentration: 116000 nM
Compound 3: middle estimate off by 1.6-fold (0.19 log units), on the high side; the range from low to high includes it.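

For the compounds shown here, replacing isopropyl with sec-butyl gives the first step that can be read at this position in this assay: an at least 1.7-fold lower number from compound 2 to compound 3 (0.23 log units; that floor lies within the scatter). This step is only a floor, and even that floor does not clear the usual scatter, so the added methyl cannot be said to change the read-out, because one end of the step is a limit: the limit of > 200000 nM in this assay, at which 1 of the 3 values shown sits.
With the sec-butyl chain kept, cyclopentyl in place of benzyl on the amide-type nitrogen gives a 1.4-fold lower number from compound 1 to compound 3 (0.15 log units; within the scatter), so these two amide groups cannot be told apart on this read-out.

As far as these compounds go, it remains open whether a longer chain, such as n-pentyl, or a chain ending in an amine or a carboxylic acid would shift the number beyond the scatter at this position. From the compounds shown here alone, it is equally open whether a phenyl or a piperidine group on the amide-type nitrogen would do so.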